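The source may report more compounds than this note shows. Statements on the series, on what has been measured and on what is new or still open speak of the compounds shown alone.

Measured so far in a functional assay on T47D cells (Homo sapiens) for inhibition, read by sulforhodamine B assay, with a stated time of 48 h; a higher number here means a weaker inhibitor of growth, a lower number a stronger inhibitor of growth:
Compound 1 `COc1cc(-c2nn(-c3cccc(NC(=O)Nc4cccc(C(F)(F)F)c4)c3)cc2-c2ccncc2)ccc1Cl` gives 1650 nM.
Compound 2 `COc1cc(-c2nn(-c3cccc(NC(=O)Nc4ccc(Cl)c(C(F)(F)F)c4)c3)cc2-c2ccncc2)ccc1Cl` gives 1230 nM.

Compound 2 has the lower of the two numbers in this assay, but the step of a 1.3-fold lower number from compound 1 to compound 2 (0.13 log units; within the scatter) is within the scatter, so the two compounds are not separated. Compound 3 `COc1cc(-c2nn(-c3cccc(NC(=O)c4ccccc4)c3)cc2-c2ccncc2)ccc1Cl` is not yet measured. It differs from compound 2 by phenyl in place of (4-chloro-3-(trifluoromethyl)phenyl)amino on a carbonyl carbon. Among the measured compounds shown here, the only measured step, from compound 1 to compound 2, exchanges a single substituent on the outer aromatic ring and leaves the rest of the molecule as it is; no measured pair removes the amino group together with the substituted ring, so no measured step bears directly on this change, and the expectation rests on the structural change alone. Compound 3 is expected to give a higher number in this assay, by a step of a 4.1-fold higher number from compound 2 to compound 3 (0.61 log units; beyond the scatter) that would lie beyond the scatter. For compound 3 the estimate is 5000 nM, with a range from 1500 nM to 20000 nM.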

Compound 3, concentration for 50% growth inhibition: 1900 nM
Beside the measured number, compound 3's estimate is 2.6-fold (0.42 log units) above it, within the range that was stated.
By their numbers in this assay, from the lowest: compounds 2, 1 and 3 (each within the scatter of the next).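

In this assay, phenyl in place of (4-chloro-3-(trifluoromethyl)phenyl)amino on the carbonyl carbon gives a 1.5-fold higher number from compound 2 to compound 3 (0.19 log units; within the scatter), and phenyl in place of (3-(trifluoromethyl)phenyl)amino gives a 1.2-fold higher number from compound 1 to compound 3 (0.06 log units; within the scatter). The earlier pair tested only a chloro on the outer ring; these steps show that at this position the whole substituted arylamino group can be exchanged for plain phenyl, with its amino hydrogen-bond donor, trifluoromethyl and any chloro gone, without separating the compounds. No measurement shown here gives a reason for this flat result.

On these data alone, whether an aromatic ring on the carbonyl carbon matters at all stays open, as all three compounds carry one there. A methyl on that carbon, or a free amine in place of the whole amide, would address this, as would a carboxylic acid on the phenyl ring.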